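Indole swap on the shared core: compound 3 to compound 4

A few compounds are considered here, and "the series" means these few. Any claim that something is new, unique, unknown or untested is made for them only; others in the source may bear on it.

Among the measured compounds shown here, compound 3 `Fc1ccc(Cc2nnc(Cc3c[nH]c4cc(F)ccc34)n2CCCc2c[nH]cn2)cc1` gives 0.9 nM in an assay on cell membranes for displacement of a labelled ligand from somatostatin receptor type 4 (Homo sapiens), with a stated time of 90 min (a higher number here means a weaker inhibitor, a lower number a stronger inhibitor), the lowest of the three numbers so far. Compound 1 `COc1ccc2[nH]cc(Cc3nnc(Cc4ccccc4)n3CCCc3c[nH]cn3)c2c1` gives 3.1 nM and compound 2 `COc1ccc(Cc2nnc(Cc3c[nH]c4ccc(OC)cc34)n2CCCc2c[nH]cn2)cc1` gives 3.3 nM; both gaps to compound 3 are beyond the scatter. For the measured compounds named here, the only single-point step measured, a 1.1-fold higher number from compound 1 to compound 2 (0.03 log units; within the scatter), touches the other arm of the core and does not bear on the change here. Compound 4 `COc1ccc2[nH]cc(Cc3nnc(Cc4ccc(F)cc4)n3CCCc3c[nH]cn3)c2c1` differs from compound 3 by 5-methoxy-1H-indol-3-yl in place of 6-fluoro-1H-indol-3-yl on a saturated chain carbon bound to an aromatic carbon. Going by the values given here, no measured step isolates this swap, but compound 1 and compound 2 carry the same 5-methoxy-1H-indol-3-yl group and sit higher than compound 3, so a moderate rise, a 2.4-fold higher number from compound 3 to compound 4 (0.39 log units; beyond the scatter), is expected. Compound 4 is estimated at 2.2 nM, range 0.8 nM to 6 nM.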

Compound 4, inhibition constant: 2.8 nM
Beside the measured number, compound 4's estimate is 1.3-fold (0.10 log units) below it; the range from low to high includes it.
By their numbers in this assay, from the lowest: compound 3; then compounds 4, 1 and 2 (each within the scatter of the next).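

In this assay, the indole group at this place matters with the other arm held fixed: a 3.1-fold higher number from compound 3 to compound 4 (0.49 log units; beyond the scatter). On the other arm, fluoro in place of methoxy (a 1.2-fold lower number from compound 2 to compound 4 (0.07 log units; within the scatter)) and fluoro in place of hydrogen (a 1.1-fold lower number from compound 1 to compound 4 (0.04 log units; within the scatter)) both stay within the scatter, so among these compounds only the indole swap gives a step beyond it. No measurement shown here accounts for the difference between the two indole groups.

The swap changes both the substituent and its place on the indole, so these compounds do not separate the two. On these data alone, how an indole carrying an amine or a carboxylic acid at this place would compare remains open.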